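The compounds below may be only part of what the source reports. "The series", "measured", "known", "first", "only" and "open" are said of these compounds alone.

Values in a functional assay on A-375 cells (Homo sapiens) for cytotoxicity, read by MTT assay, with a stated time of 72 h; on this read-out higher numbers stand for weaker inhibition and lower numbers for stronger inhibition:
- compound 1 `O=C1c2c[n+]([O-])c3ccccc3c2C(=O)c2c1c1ccccc1n2Cc1cn(CC(O)CO)nn1`: 440 nM
- compound 2 `O=C1c2c[n+]([O-])c3ccccc3c2C(=O)c2c1c1ccccc1n2CCN1CCCCC1`: 180 nM

Compound 2, at 180 nM, holds the lower of the two numbers, and so far the stronger inhibition. Compound 3 `O=C1c2c[n+]([O-])c3ccccc3c2C(=O)c2c1c1ccccc1n2CCCN1CCC(O)CC1` has not yet been measured. Its change from compound 2 is (4-hydroxypiperidin-1-yl)methyl in place of piperidin-1-yl on a saturated chain carbon, two bonds along the chain from an aromatic nitrogen. In other words, 2-(piperidin-1-yl)ethyl gives way to 3-(4-hydroxypiperidin-1-yl)propyl.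

For the measured compounds named here, only one measured step bears on this: a 2.4-fold lower number from compound 1 to compound 2 (0.39 log units; beyond the scatter). That step is modest and only an indirect guide. It replaces a 1-(2,3-dihydroxypropyl)-1H-1,2,3-triazol-4-yl group with (piperidin-1-yl)methyl, so the number falls as a hydroxyl-carrying group leaves, but much else changes with it. Going by the values given here, no measured pair isolates the added hydroxyl or the longer chain. In this assay the expectation is therefore no step beyond the scatter, with a lean toward a higher number. The expected change is a 1.4-fold higher number from compound 2 to compound 3 (0.16 log units; within the scatter). For compound 3 the estimated value is 260 nM, with an expected range of 90 nM to 750 nM.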

Compound 3, half-maximal inhibitory concentration: 240 nM
For compound 3 the middle estimate is 1.1-fold (0.03 log units) above the measured one, and the stated range covers the measured number.
By their numbers in this assay, from the lowest: compounds 2, 3 and 1 (each within the scatter of the next, the first and the last beyond it).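

In this assay, the change from 2-(piperidin-1-yl)ethyl to 3-(4-hydroxypiperidin-1-yl)propyl gives a 1.3-fold higher number from compound 2 to compound 3 (0.12 log units; within the scatter) and so does not move the read-out beyond the scatter, even though a hydroxyl and a longer chain enter together on a saturated chain carbon, two bonds along the chain from an aromatic nitrogen. The replacement of 1-(2,3-dihydroxypropyl)-1H-1,2,3-triazol-4-yl by 2-(4-hydroxypiperidin-1-yl)ethyl gives a 1.8-fold lower number from compound 1 to compound 3 (0.26 log units; within the scatter), so this hydroxyl-bearing piperidine, unlike the unsubstituted piperidine of compound 2, does not separate from the triazole group beyond the scatter. No measurement shown here accounts for this result.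

The two parts of the change remain confounded: the pair 3-(piperidin-1-yl)propyl and 2-(4-hydroxypiperidin-1-yl)ethyl would be needed to read the hydroxyl and the chain length separately, and a small opposing contribution from each cannot be ruled out. Also open, as far as these compounds go, is whether other ring amines or substituents at this place, such as morpholine, piperazine or a carboxylic acid on the piperidine, or a butyl linker, would give a step beyond the scatter.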